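Extending an ester chain on a phosphate prodrug: expected stability

The source may report more compounds than this note shows. Statements on the series, on what has been measured and on what is new or still open speak of the compounds shown alone.

Compound 1 `CCCCCCCCCCCCCCCCOC(=O)Oc1ccc(COP(=O)(OCc2ccc(OC(=O)CC)cc2)OP(=O)(O)OP(=O)(O)OC[C@@H]2O[C@H](n3cc(F)c(N)nc3=O)CS2)cc1` is tested in a physicochemical assay for metabolic stability, read by HPLC, in phosphate buffer, at pH 7.3 (on this read-out higher numbers stand for a longer-lived compound and lower numbers for a shorter-lived compound), where compound 1 gives 45 h. Compound 2 `CCCCCCCCCCCCCCCCOC(=O)Oc1ccc(COP(=O)(OCc2ccc(OC(=O)CCCC)cc2)OP(=O)(O)OP(=O)(O)OC[C@@H]2O[C@H](n3cc(F)c(N)nc3=O)CS2)cc1` carries ethyl in place of hydrogen on a saturated chain carbon, two bonds along the chain from a carbonyl carbon and in this assay compound 2 gives 36 h, a step of a 1.3-fold lower number from compound 1 to compound 2 (0.10 log units; within the scatter). Compound 3 `CCCCCCCCCCCCCCCCOC(=O)Oc1ccc(COP(=O)(OCc2ccc(OC(=O)CC)cc2)OP(=O)(O)OP(=O)(O)OC[C@H]2O[C@@H](n3cc(Cl)c(=O)[nH]c3=O)C[C@@H]2F)cc1` has a different core; the difference between the two cores is not broken down here. In this assay compound 3 gives 56 h, within the scatter of compound 1 and compound 2. Compound 4 `CCCCCCCCCCCCCCCCOC(=O)Oc1ccc(COP(=O)(OCc2ccc(OC(=O)CCCC)cc2)OP(=O)(O)OP(=O)(O)OC[C@H]2O[C@@H](n3cc(Cl)c(=O)[nH]c3=O)C[C@@H]2F)cc1` is not yet measured and differs from compound 3 by ethyl in place of hydrogen on a saturated chain carbon, two bonds along the chain from a carbonyl carbon, the same change seen from compound 1 to compound 2. Because that earlier change gave a 1.3-fold lower number from compound 1 to compound 2 (0.10 log units; within the scatter), a similar step of a 1.2-fold lower number from compound 3 to compound 4 (0.09 log units; within the scatter) is expected here. Compound 4 is therefore estimated to give 45 h, expected between 28 h and 70 h.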

Compound 4, half-life: 66 h
Estimate against measurement, compound 4: 1.5-fold (0.17 log units) below, within the range that was stated.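

In this assay, putting ethyl in place of hydrogen on a saturated chain carbon, two bonds along the chain from a carbonyl carbon, gives a 1.2-fold higher number from compound 3 to compound 4 (0.07 log units; within the scatter) on one core and a 1.3-fold lower number from compound 1 to compound 2 (0.10 log units; within the scatter) on the other. Both steps lie within the scatter, so on these two cores the change shows no effect that can be told apart from repeat-measurement noise, and the opposite directions cannot be read as a reversal between cores. Nothing available here accounts for the stability of these compounds.

One pair on each of two cores sets no rule for a third core. Going by these compounds, whether a longer chain, an amine or a carboxylic acid on that carbon would give a step beyond the scatter stays open.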